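Linker extension from compound 2 in the kinase series

The source may hold more compounds than are shown below. What is called first, only, known or untested is meant among the compounds shown, and "the series" means these compounds.

In an assay on isolated protein for inhibition of protein kinase C delta type (Homo sapiens), read by TR-FRET, with a stated time of 2 h (on this read-out lower numbers stand for stronger inhibition and higher numbers for weaker inhibition), compound 1 `N#Cc1cnc(NCc2cnccc2C(F)(F)F)cc1N[C@H]1CC[C@@H](O)CC1` gives 4500 nM. Among the measured compounds shown here, compound 2 `N#Cc1cnc(NCc2cnccc2C(F)(F)F)cc1NC1CCOCC1` gives 9800 nM in this assay, the higher of the two numbers so far; the only measured step is a 2.2-fold higher number from compound 1 to compound 2 (0.34 log units; beyond the scatter), a swap of one saturated ring for another. Compound 3 `N#Cc1cnc(NCc2cnccc2C(F)(F)F)cc1NCCC1CCOCC1` carries 2-(oxan-4-yl)ethyl in place of oxan-4-yl on a nitrogen on an aromatic ring. For the measured compounds named here, no measured step bears on this change: the step from compound 1 to compound 2 alters the ring itself, not the length of the link between the ring and the nitrogen, so it offers no direct guide, and nothing in the two values shown points to a gain. The expected step is a 1.5-fold higher number from compound 2 to compound 3 (0.18 log units; within the scatter), a modest move toward weaker inhibition or none beyond the scatter. Compound 3 is accordingly expected at about 15000 nM in this assay, with a range from 4000 nM to 50000 nM.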

Compound 3, half-maximal inhibitory concentration: > 10000 nM
Compound 3 ended at the assay's limit; the forecaster's own chance of this, stated with the estimate: 20%; the middle value is on the limit's open side.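

Compound 3 reads > 10000 nM in this assay, a limit of the assay and not a number: the limit of > 10000 nM in this assay, at which 1 of the 3 values shown sits. Extending (oxan-4-yl)amino to (2-(oxan-4-yl)ethyl)amino gives an at least 1.0-fold higher number from compound 2 to compound 3 (0.00 log units; that floor lies within the scatter), so the longer link on this nitrogen shows no stronger inhibition, while any weakening cannot be sized. The 4-hydroxycyclohexyl group keeps the lower number against the extended group, with an at least 2.2-fold higher number from compound 1 to compound 3 (0.34 log units; beyond the scatter), a gap beyond the scatter even as a floor.

As far as these compounds go, how far compound 3 lies past the limit remains open, as does the effect of the same longer link on 4-hydroxycyclohexyl. Also open, from the compounds shown here alone, is whether an amine or a carboxylic acid on the saturated ring of this substituent would give a lower number in this assay.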